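Acetyl on the Chain Amine of Compound 2

The compounds below may be only part of what the source reports. "The series", "measured", "known", "first", "only" and "open" are said of these compounds alone.

Compound 1 `Cc1cc(OCCN)cc(C)c1Cc1ccc(N)cc1` gives 134 nM in a functional assay on HEK293T cells for agonist activity at trace amine-associated receptor 1 (Mus musculus), read by BRET and cAMP accumulation; a lower number here means that less compound is needed, a higher number that more compound is needed for the effect. Compound 2 `CC(=O)Nc1ccc(Cc2ccc(OCCN)cc2)cc1` returns only > 10000 nM in this assay, a limit of the measurement and not a number (the limit of > 10000 nM in this assay, at which 1 of the 2 values shown sits). Compound 3 `CC(=O)NCCOc1ccc(Cc2ccc(NC(C)=O)cc2)cc1` differs from compound 2 by acetyl in place of hydrogen on an amine nitrogen. Among the compounds with values here, since compound 2 already sits at the limit, no measured step is available here, and the change is expected to give a step that the limit leaves unreadable from compound 2 to compound 3, most likely another limit. Compound 3 is estimated at 20000 nM, within 5000 nM to 100000 nM.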

Compound 3, half-maximal effective concentration: > 10000 nM
Compound 3: a limit, no number; the forecaster's own chance of this, stated with the estimate: 85%; the middle value lies beyond the limit too.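

No step can be read from compound 2 to compound 3, since both values are limits of the measurement and not numbers: the limit of > 10000 nM in this assay, at which 2 of the 3 values shown sit.

The compounds shown leave open whether acetyl in place of hydrogen on the amine nitrogen changes the response in this assay at all.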